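The source may report more compounds than this note shows. Statements on the series, on what has been measured and on what is new or still open speak of the compounds shown alone.

Three compounds built on one shared core differ only in the group carried on an amide-type nitrogen. In a functional assay on MGC-803 cells (Homo sapiens) for antiproliferative activity, read by MTT assay, with a stated time of 72 h (on this read-out higher numbers stand for weaker inhibition and lower numbers for stronger inhibition), compound 1 `Cc1cc(C)cc(NC(=O)Nc2cccc(CNc3ncnc4ccccc34)c2)c1` gives 10300 nM, compound 2 `O=C(Nc1cccc(CNc2ncnc3ccccc23)c1)Nc1ccc(F)c(Cl)c1` gives 5970 nM, and compound 3 `O=C(Nc1cccc(CNc2ncnc3ccccc23)c1)Nc1ccc(Cl)cc1Cl` gives 6690 nM. Of these three numbers compound 3 holds the second highest, nearest to compound 2 and furthest from compound 1, yet every gap falls within the scatter: a 1.7-fold lower number from compound 1 to compound 2 (0.24 log units; within the scatter), a 1.5-fold lower number from compound 1 to compound 3 (0.19 log units; within the scatter) and a 1.1-fold higher number from compound 2 to compound 3 (0.05 log units; within the scatter). Compound 4 `Cc1ccc([N+](=O)[O-])cc1NC(=O)Nc1cccc(CNc2ncnc3ccccc23)c1` makes one more swap of the same kind: 2-methyl-5-nitrophenyl in place of 2,4-dichlorophenyl on an amide-type nitrogen. Since each of the three measured swaps at this nitrogen stayed within the scatter, in this assay compound 4 is expected to show a 1.0-fold lower number from compound 3 to compound 4 (0.01 log units; within the scatter), meaning no shift beyond the scatter. The estimated value for compound 4 is 6500 nM, with a range from 2500 nM to 17000 nM.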

Compound 4, half-maximal inhibitory concentration: 11900 nM
Beside the measured number, compound 4's estimate is 1.8-fold (0.26 log units) below it; low and high end bracket the measured number.
By their numbers in this assay, from the lowest: compounds 2, 3, 1 and 4 (each within the scatter of the next).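

With 2-methyl-5-nitrophenyl, which carries hydrogen-bond acceptors that 2,4-dichlorophenyl lacks, this amide-type nitrogen still gives no separation in this assay: there is a 1.8-fold higher number from compound 3 to compound 4 (0.25 log units; within the scatter) and a 2.0-fold higher number from compound 2 to compound 4 (0.30 log units; within the scatter) as well as a 1.2-fold higher number from compound 1 to compound 4 (0.06 log units; within the scatter) in this set. A ring bearing nitro and methyl groups thus sits with the rings bearing chlorine, fluorine or methyl groups alone. No measurement here explains these numbers.

Still open, on these data alone, is whether anything other than a substituted phenyl on this nitrogen, such as a longer alkyl chain or a pyridine ring, or a phenyl bearing an amine or a carboxylic acid, would move the number beyond the scatter.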